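Swapping the ketone-bound ring: from thiophene to aminopyrimidine

The source may report more compounds than this note shows. Statements on the series, on what has been measured and on what is new or still open speak of the compounds shown alone.

Compound 1 `COc1ccc(-c2cc3ccccc3nc2/C=C/C(=O)c2ccc(O)cc2)cc1` gives 3880 nM in a functional assay on SK-BR-3 cells (Homo sapiens) for antiproliferative activity, read by XTT assay, with a stated time of 72 h; a higher number here means a weaker inhibitor, a lower number a stronger inhibitor.
Compound 2 `COc1ccc(-c2cc3ccccc3nc2/C=C/C(=O)c2ccc(OC)cc2OC)cc1` gives 2260 nM in this assay.
Compound 3 `COc1ccc(-c2cc3ccccc3nc2/C=C/C(=O)c2cccs2)cc1` gives 800 nM in this assay.

All three share a core and differ only in the ring attached to the carbonyl carbon. Compound 3 has the lowest number of the three: a 4.9-fold lower number from compound 1 to compound 3 (0.69 log units; beyond the scatter) and a 2.8-fold lower number from compound 2 to compound 3 (0.45 log units; beyond the scatter), while a 1.7-fold lower number from compound 1 to compound 2 (0.23 log units; within the scatter). Compound 4 `COc1ccc(-c2cc3ccccc3nc2/C=C/C(=O)c2cnc(N)nc2C)cc1` carries a further change at that same position: 2-amino-4-methylpyrimidin-5-yl in place of thiophen-2-yl on a carbonyl carbon. The measured steps show that changing this ring shifts the result only modestly, and none of them involves a ring like the one entering here. A modest move away from the best number seems more likely than a further gain; the expected step is a 1.9-fold higher number from compound 3 to compound 4 (0.27 log units; within the scatter). Compound 4 is thus estimated at 1500 nM, within 500 nM to 5000 nM.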

Compound 4, half-maximal inhibitory concentration: > 10000 nM
Compound 4: no number, only a limit; the forecaster's own chance of this, stated with the estimate: 5%; at least 6.6-fold (0.82 log units) between middle value and limit.
By their numbers in this assay, from the lowest: compound 3; then compounds 2 and 1 (each within the scatter of the next). At a limit, above all of these: compound 4.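

For compound 4 the result is a limit of the assay, not a number: the limit of > 10000 nM in this assay, at which 1 of the 4 values shown sits. The ring on the carbonyl carbon can matter far more than the earlier swaps showed: 2-amino-4-methylpyrimidin-5-yl falls behind thiophen-2-yl (an at least 12-fold higher number from compound 3 to compound 4 (1.09 log units; beyond the scatter)), 2,4-dimethoxyphenyl (an at least 4.4-fold higher number from compound 2 to compound 4 (0.64 log units; beyond the scatter)) and 4-hydroxyphenyl (an at least 2.5-fold higher number from compound 1 to compound 4 (0.41 log units; beyond the scatter)).

The amino group, the methyl group and the ring nitrogens all enter together, and these compounds cannot separate them. Going by these compounds, how a plain pyrimidin-5-yl ring, carrying neither amine nor methyl, would behave here also stays open.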